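The compounds below may be only part of what the source reports. "The series", "measured", "known", "first", "only" and "open" are said of these compounds alone.

Compound 2, `COc1ccccc1C#Cc1cc(Cl)cn2c([N+](=O)[O-])c(CS(=O)(=O)c3ccccc3)nc12`, carries a 2-methoxyphenyl on its alkyne. In an ADME assay on HepG2 cells (Homo sapiens) for cytotoxicity, read by MTT assay, with a stated time of 72 h (a higher number here means that more compound is tolerated, a lower number that less compound is tolerated), compound 2 is read only as a limit, > 3900 nM, so no true number is known for it. Compound 1, `O=[N+]([O-])c1c(CS(=O)(=O)c2ccccc2)nc2c(C#Cc3ccccc3)cc(Cl)cn12`, likewise gives in this assay only a limit, > 3900 nM. Compound 3, `O=[N+]([O-])c1c(CS(=O)(=O)c2ccccc2)nc2c(C#Cc3cccc(F)c3)cc(Cl)cn12`, also reaches in this assay no more than a limit, > 3900 nM. The changes from compound 1 to compound 2 (a step that the two limits leave unreadable from compound 1 to compound 2), from compound 1 to compound 3 (a step that the two limits leave unreadable from compound 1 to compound 3) and from compound 2 to compound 3 (a step that the two limits leave unreadable from compound 2 to compound 3) cannot be sized, because of the limit of > 3900 nM in this assay, at which 3 of the 3 values shown sit. Compound 4, `CC(C)(O)C#Cc1cc(Cl)cn2c([N+](=O)[O-])c(CS(=O)(=O)c3ccccc3)nc12`, differs from compound 2 in one place: 1-hydroxy-1-methylethyl in place of 2-methoxyphenyl on a triple-bonded carbon. Among the compounds with values here, none of the measured steps shows a readable effect on this assay, and every compound so far sits at the same limit, so no step beyond the scatter is anticipated in either direction. Compound 4 is therefore expected to give in this assay about 6000 nM, with a range from 2500 nM to 20000 nM, most likely reported again as a limit. The expected step from compound 2 to compound 4 is a step that the limit leaves unreadable from compound 2 to compound 4.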

Compound 4, half-maximal cytotoxic concentration: > 62500 nM
Compound 4 gave a limit, no number; the forecaster's own chance of this, stated with the estimate: 80%; middle value at least 10-fold (1.01 log units) from the limit.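

In this assay compound 4 gives only a limit, > 62500 nM. The steps to compound 4 from compound 1, compound 2 and compound 3 cannot be read. The compounds shown leave open the true value of each compound, and whether changing the group on the triple-bonded carbon shifts it at all.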